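Dropping the Pyridine Ring from the Piperazine Substituent

The compounds below may be only part of what the source reports. "The series", "measured", "known", "first", "only" and "open" are said of these compounds alone.

Of the compounds shown here, three sharing one core have been tested so far. In an ADME assay on microsomes from liver (Homo sapiens) for metabolic stability, read by LC-MS, with a stated time of 10 min (on this read-out lower numbers stand for a less stable compound and higher numbers for a more stable compound), compound 1 `CN(C[C@H]1Cc2c(cccc2N2CCN(Cc3ccccn3)CC2)CN1)[C@H]1CCCc2cccnc21` gives 4.2%, the lowest of the three. Compound 2 `CN(C[C@H]1Cc2c(cccc2N2CCNCC2)CN1)[C@H]1CCCc2cccnc21` gives 99.7% and compound 3 `CN(C[C@H]1Cc2c(cccc2N2CCN(c3ncccn3)CC2)CN1)[C@H]1CCCc2cccnc21` gives 35.5%. The steps from compound 1 are large: a number 95.5 percentage points higher from compound 1 to compound 2 (beyond the scatter) and a number 31.3 percentage points higher from compound 1 to compound 3 (beyond the scatter).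

Compound 4 `CN1CCN(c2cccc3c2C[C@H](CN(C)[C@H]2CCCc4cccnc42)NC3)CC1` differs from compound 1 by hydrogen in place of pyridin-2-yl on a saturated chain carbon bound to an amine nitrogen in a ring, so that (pyridin-2-yl)methyl becomes methyl. Both measured changes at this ring nitrogen raised the percent remaining strongly, and the present change keeps only the methyl of that group. A large rise in this assay is therefore expected, as a number 65.8 percentage points higher from compound 1 to compound 4 (beyond the scatter). Compound 4 is estimated to give 70%, with a range from 35% to 98%.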

Compound 4, percent of the compound remaining: 75.8%
Compound 4: the middle estimate sits 5.8 percentage points below what was measured; the range from low to high includes it.
By their numbers in this assay, from the lowest: compound 1; then compound 3; then compound 4; then compound 2.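

Removing just the pyridin-2-yl and keeping the methyl gives a number 71.6 percentage points higher from compound 1 to compound 4 (beyond the scatter) and so recovers most of the stability that compound 2 shows. The methyl still carries a cost, seen as a number 23.9 percentage points lower from compound 2 to compound 4 (beyond the scatter), so an unsubstituted ring nitrogen remains the best of the four. Methyl also outperforms the directly attached pyrimidin-2-yl, with a number 40.3 percentage points higher from compound 3 to compound 4 (beyond the scatter) as the step between them.

From the compounds shown here alone, whether an ethyl group or a longer chain on this nitrogen would keep the percent remaining high stays open. Nothing shown here explains why these groups differ.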